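The source may report more compounds than this note shows. Statements on the series, on what has been measured and on what is new or still open speak of the compounds shown alone.

Measured so far: compound 1 `COCCOCn1cc[n+](C)c1/C=N/O` gives -2.81 in a physicochemical assay for lipophilicity; a lower number here means a more polar compound, a higher number a more lipophilic compound; compound 2 `COC(C)CCOCn1cc[n+](C)c1/C=N/O` gives -2.22 in this assay.

Compound 2 stands highest of the two numbers; its nearest neighbour is compound 1, separated by a number 0.59 log units higher from compound 1 to compound 2 (beyond the scatter). Compound 3 `C[n+]1ccn(COCC[Si](C)(C)C)c1/C=N/O` differs from compound 2 by a group of 4 heavy atoms (3 carbon, 1 silicon; no ring) in place of a group of 4 heavy atoms (3 carbon, 1 oxygen; no ring), on a saturated chain carbon, two bonds along the chain from an oxygen on a saturated carbon. Within the data shown here, only one measured step bears on this change, a number 0.59 log units higher from compound 1 to compound 2 (beyond the scatter), a modest rise when the chain end grew. The entering group carries no oxygen and no hydrogen-bond acceptor, so a further rise in this assay beyond the scatter is expected, a number 0.92 log units higher from compound 2 to compound 3 (beyond the scatter). Compound 3 is estimated at -1.3, with a range from -2 to -0.6.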

Compound 3, distribution coefficient: -0.34
Beside the measured number, compound 3's estimate is 0.96 log units below it; measured number above the stated range.
By their numbers in this assay, from the lowest: compound 1; then compound 2; then compound 3.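

In this assay the silicon-bearing group in place of 1-methoxyethyl gives a number 1.88 log units higher from compound 2 to compound 3 (beyond the scatter) at this place, although both groups have 4 heavy atoms, so heavy-atom count alone does not set the number here. Against the methoxy end of compound 1 the same group gives a number 2.47 log units higher from compound 1 to compound 3 (beyond the scatter) and thus extends the range at this position well past the earlier modest step. Nothing available here accounts for the size of these steps.

Silicon and the loss of the hydrogen-bond acceptor change together across compound 2 and compound 3, so their contributions stay unseparated. A tert-butyl group or an amine at this place would be needed to read them apart.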